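The source may report more compounds than this note shows. Statements on the series, on what has been measured and on what is new or still open speak of the compounds shown alone.

Within the data shown here, in an ADME assay on HEK-293T cells (Homo sapiens) for cytotoxicity, read by luminescence, with a stated time of 24 h (on this read-out higher numbers stand for lower toxicity in this test and lower numbers for higher toxicity in this test), compound 2 `CCCNC(=O)C1CCN(C(=O)c2cc3sc(CNCc4ccccc4)cc3n2Cc2ccc(OC)cc2)CC1` gives 46800 nM, the only true number so far. Compound 1 `CCCNC(=O)C1CCN(C(=O)c2cc3sc(Br)cc3n2Cc2ccc(OC)cc2)CC1` stands at > 100000 nM, which is a limit of the assay and not a number. Among the measured compounds shown here, the one measured step is therefore bounded on one side only, as the limit of > 100000 nM in this assay, at which 1 of the 2 values shown sits, shows.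

Compound 3 `CCCNC(=O)C1CCN(C(=O)c2cc3sc(CO)cc3n2Cc2ccc(OC)cc2)CC1` keeps the shared core and changes one group from compound 2: hydroxy in place of benzylamino on a saturated chain carbon bound to an aromatic carbon. This places hydroxy in place of benzylamino on a saturated chain carbon bound to an aromatic carbon, so (benzylamino)methyl gives way to hydroxymethyl.

For the measured compounds named here, the only measured step bearing on this change is an at least 2.1-fold lower number from compound 1 to compound 2 (0.32 log units; beyond the scatter), in which (benzylamino)methyl took the place of bromo. Going by the values given here, no measured step covers hydroxymethyl itself, so the read-across is loose. Losing the benzylamino should partly or wholly reverse that drop in this assay, and a reading at the limit would not be surprising. The expected step is a 1.7-fold higher number from compound 2 to compound 3 (0.23 log units; within the scatter), towards higher numbers and lower toxicity in this test. For compound 3 the estimated value is 80000 nM, with an expected range of 40000 nM to 160000 nM.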

Compound 3, half-maximal cytotoxic concentration: 15500 nM
Estimate against measurement, compound 3: 5.2-fold (0.71 log units) above; the whole stated range lies above it.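

In this assay, the loss of benzylamino does not move the number back towards the bromo compound; it moves it the other way, with a 3.0-fold lower number from compound 2 to compound 3 (0.48 log units; beyond the scatter). Both groups on the saturated chain carbon lower the number relative to bromo, and the hydroxymethyl group does so with an at least 6.4-fold lower number from compound 1 to compound 3 (0.80 log units; beyond the scatter), so among these three compounds neither the benzylamino nitrogen nor its six-membered aromatic ring is needed for the lower number, and compound 3 stands lowest and is the most toxic in this test. Compound 1 alone is held at a limit of the assay and not a number, so both steps starting from it are bounded on one side only: the limit of > 100000 nM in this assay, at which 1 of the 3 values shown sits.

Open, from the compounds shown here alone, is whether the lower number of compound 3 belongs to the hydroxy itself or to any small group on this saturated chain carbon, which a methoxymethyl, an aminomethyl or a carboxylic acid at the same place would help separate. Open too, going by these compounds, is how much of the gap between compound 2 and compound 3 rests with the phenyl ring, which a methylamino group in place of benzylamino would address.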